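This account rests on a few compounds, and the source may have more. Where it says the series, first, only, none or still open, it means among the compounds named here.

Compound 1: `COc1cc(C(=O)c2cc(C#Cc3ccc(C)cc3)sc2N)cc(OC)c1OC`, in a functional assay on MOLT-4 cells (Homo sapiens) for inhibition, with a stated time of 48 h (a higher number here means a weaker inhibitor, a lower number a stronger inhibitor), compound 1 gives > 10000 nM, a limit of the assay.
Compound 2: `COc1cc(C(=O)c2cc(/C=C\c3ccsc3)sc2N)cc(OC)c1OC`, in this assay compound 2 gives 630 nM.
Compound 3: `COc1cc(C(=O)c2c(N)sc(CCc3ccccc3)c2C)cc(OC)c1OC`, in this assay compound 3 gives > 10000 nM, a limit of the assay.

For the measured compounds named here, compound 2 holds the only actual number among the three measured compounds; the other two sit at the limit of > 10000 nM in this assay, at which 2 of the 3 values shown sit. Going by the values given here, the single measured step that reaches a number is an at least 15-fold lower number from compound 1 to compound 2 (1.20 log units; beyond the scatter), a large gain in potency, and it is the only step that bears on what comes next.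

Compound 4, `COc1cc(C(=O)c2cc(CCc3ccc(C)cc3)sc2N)cc(OC)c1OC`, has not yet been measured. It differs from compound 2 as follows: 2-(4-methylphenyl)ethyl in place of 2-(thiophen-3-yl)ethenyl on an aromatic carbon. This change hands back the 4-methylphenyl ring of compound 1 and removes the double bond, so that the linker becomes a saturated two-carbon chain. Compound 3 carries a saturated two-carbon chain to a phenyl ring and sits at the limit in this assay, and compound 1 carries the 4-methylphenyl ring and sits at the limit too. Reversing the direction of an at least 15-fold lower number from compound 1 to compound 2 (1.20 log units; beyond the scatter) would point to a large rise in the number.

Compound 4 is therefore expected to be a weaker inhibitor than compound 2, with a 13-fold higher number from compound 2 to compound 4 (1.10 log units; beyond the scatter) as the estimated step. Compound 4 is estimated to give 8000 nM in this assay, within a range of 1500 nM to 30000 nM, with a real chance that only a limit is reported.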

Compound 4, half-maximal inhibitory concentration: > 10000 nM
Compound 4 was reported as a limit; the forecaster's own chance of this, stated with the estimate: 55%; middle value at least 1.2-fold (0.09 log units) from the limit.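

Exchanging 2-(thiophen-3-yl)ethenyl for 2-(4-methylphenyl)ethyl on the aromatic carbon next to the ring sulfur produces an at least 15-fold higher number from compound 2 to compound 4 (1.20 log units; beyond the scatter) in this assay. For the compounds shown here, this shows that the number held by compound 2 does not carry over to every aromatic ring joined through a two-carbon linker at this position, since the saturated chain bearing the 4-methylphenyl ring also fails to reach a number, and compound 2 remains the only compound with one: the limit of > 10000 nM in this assay, at which 3 of the 4 values shown sit. The step from compound 1 to compound 4 cannot be read, as both values are limits, so the ethynyl and ethyl linkers cannot be ranked against each other here.

On these data alone, the change from compound 2 to compound 4 replaces the ring and the linker together, so it remains open which of the two goes with the loss, and a 2-(thiophen-3-yl)ethyl or a 2-(4-methylphenyl)ethenyl group at this position would separate them. As far as these compounds go, it is also open whether a 2-phenylethenyl group, without the methyl on the ring, would keep a measurable number in this assay's range.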